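Adding chloro to compound 3

A few compounds are considered here, and "the series" means these few. Any claim that something is new, unique, unknown or untested is made for them only; others in the source may bear on it.

In a functional assay on ASPC1 cells (Homo sapiens) for antiproliferative activity, read by sulforhodamine B assay, with a stated time of 48 h (on this read-out lower numbers stand for stronger inhibition and higher numbers for weaker inhibition), compound 3 (`CO/N=C1/C(=O)N(CCCCCCC(=O)NO)c2ccccc21`) gives 1220 nM as its value. That lies within the scatter of compound 1 (`O=C(CCCCCCN1C(=O)/C(=N\O)c2cc(F)ccc21)NO`), which gives 1720 nM here. Compound 2 (`O=C(CCCCCCN1C(=O)/C(=N\O)c2cc(Br)ccc21)NO`) gives 80 nM and stands clearly lower than both, which means stronger inhibition.

Compound 4 (`CO/N=C1/C(=O)N(CCCCCCC(=O)NO)c2ccc(Cl)cc21`) carries chloro in place of hydrogen on an aromatic carbon, a change counted as chloro in place of hydrogen on an aromatic carbon in the shared core. Among the compounds with values here, no measured step adds a halogen where hydrogen stood. The closest guide is a 22-fold lower number from compound 1 to compound 2 (1.33 log units; beyond the scatter) with bromo in place of fluoro on an aromatic carbon, a large step. Going by these compounds, it is a loose guide, since compounds 1 and 2 carry a hydroxy group where compounds 3 and 4 carry methoxy, and chloro itself is untested.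

A step to a lower number in this assay is therefore expected, beyond the scatter but smaller than that bromo step. The estimated change is a 3.5-fold lower number from compound 3 to compound 4 (0.54 log units; beyond the scatter) and remains uncertain. Compound 4 is expected at 350 nM with an estimated range from 90 nM to 1300 nM for now.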

Compound 4, half-maximal inhibitory concentration: 490 nM
For compound 4 the middle estimate is 1.4-fold (0.15 log units) below the measured one; the range from low to high includes it.
By their numbers in this assay, from the lowest: compound 2; then compound 4; then compounds 3 and 1 (each within the scatter of the next).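

Chloro in place of hydrogen on this aromatic carbon gives a 2.5-fold lower number from compound 3 to compound 4 (0.40 log units; beyond the scatter) in this assay. Within the data shown here, this is the first direct comparison of a halogen with hydrogen at this position, and it shows that adding chloro to the methoxy compound is enough to lower the number beyond the scatter, though by a modest step. The earlier step, a 22-fold lower number from compound 1 to compound 2 (1.33 log units; beyond the scatter), only compared one halogen with another in compounds carrying a hydroxy group, and no measurement here explains either step.

Going by these compounds, it remains open whether chloro would give a similar step in the compounds carrying a hydroxy group, and whether bromo would outdo chloro on the methoxy compound. Also open, on these data alone, is how a non-halogen group such as a nitrile or an amine would behave on this same aromatic carbon.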